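Sulfur to Selenium on the Shared Core: Cell Toxicity

The compounds below may be only part of what the source reports. "The series", "measured", "known", "first", "only" and "open" are said of these compounds alone.

Compound 1, `O=C(/N=C(/NC(=O)c1cc(-c2ccccc2)nc2ccccc12)[Se]Cc1ccccc1)c1cc(-c2ccccc2)nc2ccccc12`, in a functional assay on PC-3 cells (Homo sapiens) for cytotoxicity, read by MTT assay, with a stated time of 72 h (a lower number here means that less compound is tolerated, a higher number that more compound is tolerated), gives only the assay limit > 100000 nM.
Compound 2, `CS/C(=N\C(=O)c1cc(-c2ccccc2)nc2ccccc12)NC(=O)c1cc(-c2ccccc2)nc2ccccc12`, in this assay gives only the assay limit > 100000 nM.

For the measured compounds named here, compound 2 stands on a limit rather than a number in this assay, and the same is true of the one other compound measured, so its place among them cannot be ranked. The step from compound 2 to compound 3, `C[Se]/C(=N\C(=O)c1cc(-c2ccccc2)nc2ccccc12)NC(=O)c1cc(-c2ccccc2)nc2ccccc12`, is a group of 2 heavy atoms (1 carbon, 1 selenium; no ring) in place of a group of 2 heavy atoms (1 carbon, 1 sulfur; no ring), on a carbon with a double bond to nitrogen. Going by the values given here, the only measured step that touches this position is a step that the two limits leave unreadable from compound 1 to compound 2, and it is unreadable because the limit of > 100000 nM in this assay, at which 2 of the 2 values shown sit, holds both of its ends. Among the compounds with values here, no measured step therefore tells how far a change at this carbon moves the read-out, and the account can only note that neither measured compound reached a number at all. Compound 3 is expected to behave as compound 2 did, with a step that the limit leaves unreadable from compound 2 to compound 3 amounting to no step beyond the scatter, most likely again a limit. The estimate for compound 3 in this assay is 200000 nM, with a range from 50000 nM to 1000000 nM.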

Compound 3, concentration lethal to 50% of the cells: > 100000 nM
Compound 3 ended at the assay's limit; the forecaster's own chance of this, stated with the estimate: 85%; the middle value is on the limit's open side.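

In this assay compound 3 gives only a limit, > 100000 nM, and not a number. None of the steps among compound 1, compound 2 and compound 3 can be read: the limit of > 100000 nM in this assay, at which 3 of the 3 values shown sit.

The compounds shown leave open how far selenium in place of sulfur, or any other change on this carbon, moves the read-out.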